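The source may hold more compounds than are shown below. What is called first, only, known or untested is meant among the compounds shown, and "the series" means these compounds.

Compound 1 `CSc1nc(NCCCCNc2ccnc3cc(Cl)ccc23)c(C#N)c(-c2cccc([N+](=O)[O-])c2)n1`: 100000 nM
Compound 2 `CSc1nc(-c2ccc([N+](=O)[O-])cc2)c(C#N)c(N2CCN(c3ccnc4cc(Cl)ccc34)CC2)n1`: > 100000 nM

In an ADME assay on HeLa cells (Homo sapiens) for cytotoxicity, read by microscopy (on this read-out lower numbers stand for higher toxicity in this test and higher numbers for lower toxicity in this test), compound 1 gives 100000 nM. Compound 2 is recorded only as a limit of the assay, > 100000 nM, and not as a number. Compound 1 therefore stands as the only number shown; the one further value is a limit, (the limit of > 100000 nM in this assay, at which 1 of the 2 values shown sits). Within the data shown here, no step between measured compounds is available, so nothing in this set tells how a change of the aromatic group on the shared core moves the read-out. Compound 3 `COc1ccc(-c2nc(SC)nc(NCCCCNc3ccnc4cc(Cl)ccc34)c2C#N)cc1OC` differs from compound 1 by 3,4-dimethoxyphenyl in place of 3-nitrophenyl on an aromatic carbon. With compound 1 at the single number shown and the other value a limit, the expectation is that compound 3 stays in the same region, with no step beyond the scatter. The step from compound 1 to compound 3 is estimated as no change at the digits printed from compound 1 to compound 3 (within the scatter). Compound 3 is expected to give 100000 nM, in a range from 30000 nM to 100000 nM, and a limit rather than a number would not surprise.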

Compound 3, minimum cytotoxic concentration: 100000 nM
Compound 3: the middle estimate sits on the measured number at the digits printed, and the stated range covers the measured number.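

In this assay, putting 3,4-dimethoxyphenyl in place of 3-nitrophenyl gives no change at the digits printed from compound 1 to compound 3 (within the scatter). Among these compounds, this is the first comparison in the set that isolates one place, an aromatic carbon ortho to a cyano group, and it shows that the two aryl groups, one carrying a nitro group and the other two methoxy groups, cannot be told apart on this read-out. Compound 2 remains a limit of the assay and not a number, so it adds no step to this comparison: the limit of > 100000 nM in this assay, at which 1 of the 3 values shown sits.

As far as these compounds go, both aryl groups are carbon-only aromatic rings, so it remains open whether a group of another kind at this position, such as a carboxylic acid or an aliphatic amine, would give a different value. From the compounds shown here alone, it is also open whether a longer chain on the shared core would shift the read-out.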